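The source may hold more compounds than are shown below. What is called first, only, known or untested is meant among the compounds shown, and "the series" means these compounds.

Three compounds have been measured in an assay on mitochondria (strain BALB/c) for inhibition of glycerol-3-phosphate acyltransferase 1, mitochondrial (Mus musculus), read by scintillation counting, with a stated time of 10 min; a lower number here means a stronger inhibitor, a higher number a weaker inhibitor:

Compound 1, `CCCCCCCCS(=O)(=O)Nc1cc(-c2ccc(O)cc2)ccc1C(=O)O`: 64800 nM
Compound 2, `CCCCCCCCS(=O)(=O)Nc1ccc(-c2ccccc2-c2ccccc2)cc1C(=O)O`: 10100 nM
Compound 3, `CCCCCCCCS(=O)(=O)Nc1ccc(-c2ccccc2F)cc1C(=O)O`: 34600 nM

Compound 3 stands second highest of these three numbers. Its nearest neighbour is compound 1, and the gap between them lies within the usual scatter, so the two cannot be ranked against each other. For the measured compounds named here, compound 2 lies further away: the one measured step, a 3.4-fold higher number from compound 2 to compound 3 (0.53 log units; beyond the scatter), is of modest size and shows that the number rose beyond the scatter when a phenyl group on the distal ring gave way to a fluorine atom.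

Compound 4, `CCCCCCCCS(=O)(=O)Nc1ccc(CCc2ccccc2)cc1C(=O)O`, takes a different route: phenethyl in place of 2-fluorophenyl on an aromatic carbon. Going by the values given here, no measured step covers exactly this exchange. Among the compounds with values here, the only step that bears on it, from compound 2 to compound 3, concerns the same place on the shared core and shows that enlarging the group there lowered the number. Compound 4 also carries a larger group than compound 3, so a move towards a lower number is the more plausible direction, but a flexible phenethyl is not a phenyl, and any step may remain within the scatter.

Compound 4 is therefore expected to give about 25000 nM in this assay, with a likely range from 9000 nM to 70000 nM. The expected step, a 1.4-fold lower number from compound 3 to compound 4 (0.14 log units; within the scatter), is small and uncertain.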

Compound 4, half-maximal inhibitory concentration: 37500 nM
The estimate for compound 4 lay 1.5-fold (0.18 log units) below the measured number, and the stated range covers the measured number.
By their numbers in this assay, from the lowest: compound 2; then compounds 3, 4 and 1 (each within the scatter of the next).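

In this assay, exchanging 2-fluorophenyl for phenethyl at this position gives a 1.1-fold higher number from compound 3 to compound 4 (0.03 log units; within the scatter) and so leaves the number effectively unchanged, which means that these two groups cannot be told apart here. This adds a caution to the earlier step, a 3.4-fold higher number from compound 2 to compound 3 (0.53 log units; beyond the scatter). A larger group does not by itself bring a lower number: phenethyl has more heavy atoms than 2-fluorophenyl, yet compound 4 goes against any simple link between size and number, giving 37500 nM while compound 2 gives 10100 nM. No independent measurement is available to explain this result.

The compounds shown leave open whether the lower number of compound 2 depends on the particular arrangement of its two phenyl rings, or whether another group at this place, such as a pyridine ring, an amide or a benzyl ether, could also lower it. They also do not show how the number would respond to changing the link in phenethyl, whether to the single carbon of benzyl or to the longer chain of phenylpropyl.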